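The compounds below may be only part of what the source reports. "The series", "measured", "known", "first", "only" and "open" are said of these compounds alone.

Three compounds sharing one core have been measured in a functional assay on MCF7 cells (Homo sapiens) for antiproliferative activity, read by sulforhodamine B assay, with a stated time of 48 h; on this read-out higher numbers stand for weaker inhibition and lower numbers for stronger inhibition:

Compound 1 `O=C1NCCN1c1ccc(S(=O)(=O)Nc2ccc(I)cc2)cc1`: 600 nM
Compound 2 `O=C1NCCN1c1ccc(S(=O)(=O)Nc2ccc(F)c(F)c2)cc1`: 620 nM
Compound 3 `O=C1NCCN1c1ccc(S(=O)(=O)Nc2ccc(Br)cc2)cc1`: 240 nM

Compound 3 gives the lowest number of the three, and its steps to both of the others lie beyond the scatter. The next compound, compound 4 `Cc1ccc(C)c(NS(=O)(=O)c2ccc(N3CCNC3=O)cc2)c1`, keeps the core but carries 2,5-dimethylphenyl in place of 4-bromophenyl on a sulfonamide nitrogen.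

All three measured steps change this same group. The two that end at the bromo compound are a 2.5-fold lower number from compound 1 to compound 3 (0.40 log units; beyond the scatter) and a 2.6-fold lower number from compound 2 to compound 3 (0.41 log units; beyond the scatter), both modest. The remaining one is a 1.0-fold higher number from compound 1 to compound 2 (0.01 log units; within the scatter), so two quite different groups gave matching numbers. Among the compounds with values here, no measured compound carries a methyl group, which leaves the direction open to doubt. Still, each of the two other groups gave a higher number than the 4-bromophenyl of compound 3, so a modest step towards a higher number in this assay is expected, of about the same size as those two.

For compound 4 the expected step is a 2.2-fold higher number from compound 3 to compound 4 (0.34 log units; beyond the scatter). For compound 4 the estimated value is 520 nM, with an expected range from 170 nM to 1500 nM.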

Compound 4, half-maximal inhibitory concentration: 48 nM
Compound 4: middle estimate off by 11-fold (1.03 log units), on the high side; the whole stated range lies above it.
By their numbers in this assay, from the lowest: compound 4; then compound 3; then compounds 1 and 2 (each within the scatter of the next).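

The group on the sulfonamide nitrogen moves the number in this assay much further than the first three compounds showed: alongside a 5.0-fold lower number from compound 3 to compound 4 (0.70 log units; beyond the scatter) the same group gives a 13-fold lower number from compound 2 to compound 4 (1.11 log units; beyond the scatter) and a 13-fold lower number from compound 1 to compound 4 (1.10 log units; beyond the scatter) so steps at this position are no longer only modest. Compound 4 now stands lowest of the four, with each of its steps beyond the scatter, and it is the only one of them whose group on this nitrogen carries methyl groups rather than halogen, a split that no compound shown goes against. No measured finding shown explains the drop, and the counts leave little to point to, with no hydrogen-bond donors or acceptors and no net charge on either group.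

The compounds shown leave open whether both methyl groups are needed, or whether a phenyl carrying a single methyl, or ethyl groups in their place, would give a similar number. They also leave open how a methoxy group or an amine on the same ring would behave, and whether this ranking would hold outside this one antiproliferative read-out on a single cell line.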